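Working notes: fluoro to chloro on compound 3

A few compounds are considered here, and "the series" means these few. Any claim that something is new, unique, unknown or untested is made for them only; others in the source may bear on it.

Measured so far in a functional assay on MCF7 cells (Homo sapiens) for inhibition, read by MTT assay, with a stated time of 72 h (a higher number here means a weaker inhibitor, a lower number a stronger inhibitor), a short list:
- compound 1 `COc1cccc(/C=C/C(=O)Nc2cc(OC)c(OC)c(OC)c2)c1` gives 27000 nM
- compound 2 `COc1cc(NC(=O)/C=C/c2cccc(OCc3ccccc3)c2)cc(OC)c1OC` gives 2400 nM
- compound 3 `C=C(Br)C(=O)Nc1cccc(/C=C/C(=O)Nc2ccc(F)cc2)c1` gives 13600 nM

Of these three numbers, compound 3 holds the middle place only loosely. Its value lies within the scatter of compound 1, while compound 2 stands lower than both, beyond the scatter.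

The next compound to be tested is compound 4 `C=C(Br)C(=O)Nc1cccc(/C=C/C(=O)Nc2ccc(Cl)cc2)c1`, which differs from compound 3 by chloro in place of fluoro on an aromatic carbon. This is chloro in place of fluoro on an aromatic carbon, para to a large group.

Within the data shown here, only one measured step exists, and it bears on this change only weakly. That step, an 11-fold lower number from compound 1 to compound 2 (1.05 log units; beyond the scatter), is large, but it is phenyl in place of hydrogen on a saturated chain carbon bound to an oxygen on an aromatic ring. It involves neither halogen nor this place. Among the measured compounds shown here, no measured pair exchanges fluoro for chloro, so the data give no direct guide to size or direction, and its size should not be carried over. A small move at most is therefore expected in this assay, with nothing beyond the scatter.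

The expected change is a 1.4-fold lower number from compound 3 to compound 4 (0.13 log units; within the scatter), an estimate that stays within the scatter.

For compound 4 the estimated value is 10000 nM, with an expected range from 4500 nM to 22000 nM as its limits of confidence.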

Compound 4, half-maximal inhibitory concentration: 11000 nM
For compound 4 the middle estimate is 1.1-fold (0.04 log units) below the measured one, within the range that was stated.
By their numbers in this assay, from the lowest: compound 2; then compounds 4, 3 and 1 (each within the scatter of the next, the first and the last beyond it).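

In this assay the exchange of 4-fluorophenyl for 4-chlorophenyl gives a 1.2-fold lower number from compound 3 to compound 4 (0.09 log units; within the scatter), so the two halogens cannot be told apart at this aromatic carbon, para to a large group. Among these compounds, this is the first reading at this place: the one earlier step, an 11-fold lower number from compound 1 to compound 2 (1.05 log units; beyond the scatter), lies beyond the scatter but concerns another place on another set of substituents, and it said nothing about a halogen exchange here. Nothing measured on these compounds offers a reason for this result.

Going by these compounds, what remains open is whether this place responds at all to a group of a different kind, such as an amine or a carboxylic acid in place of the halogen, since fluoro and chloro alone cannot show how far the insensitivity extends. On these data alone, it is also open whether a phenyl added on the chain carbon bound to the ring oxygen, as in the step to compound 2, would bring a similarly large step on the core shared by compound 3 and compound 4.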